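The compounds below may be only part of what the source reports. "The series", "measured", "known", "first", "only" and "open" are said of these compounds alone.

Compound 1 `O=[N+]([O-])/C=C(\NC1CCCCCC1)NS(=O)(=O)c1cnccc1NC1CCCCCCC1` gives 2.59 in a physicochemical assay for lipophilicity; a lower number here means a more polar compound, a higher number a more lipophilic compound. Compound 2 `O=[N+]([O-])/C=C(\NC1CCCCCCC1)NS(=O)(=O)c1cnccc1NC1CCCCCCC1` gives 2.86 in this assay, and the step of a number 0.27 log units higher from compound 1 to compound 2 (within the scatter) places compound 2 together with compound 1 rather than apart from it. Compound 3 `O=[N+]([O-])/C=C(\NC1CCCCCCC1)NS(=O)(=O)c1cnccc1NC1CCCCC1` differs from compound 2 by cyclohexyl in place of cyclooctyl on a nitrogen on an aromatic ring. Among the measured compounds shown here, the only measured step, cyclooctyl for cycloheptyl, went in the opposite direction and stayed within the scatter; cyclohexyl for cyclooctyl is a larger change, so a fall somewhat beyond the scatter is expected. Compound 3 is estimated at 2.3, between 1.95 and 2.65, an expected step of a number 0.56 log units lower from compound 2 to compound 3 (beyond the scatter).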

Compound 3, partition coefficient: 2.27
For compound 3 the middle estimate is 0.03 log units above the measured one; the range from low to high includes it.
By their numbers in this assay, from the lowest: compound 3; then compounds 1 and 2 (each within the scatter of the next).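

In this assay, among the compounds shown here, cyclohexyl in place of cyclooctyl on a nitrogen on an aromatic ring gives a number 0.59 log units lower from compound 2 to compound 3 (beyond the scatter) and is the first step to pass beyond the scatter. For the compounds shown here, only this one change has been read at this position, so it shows that the number responds here but gives no trend across ring sizes. Nothing available accounts for the size of this step.

Open, from the compounds shown here alone, is how cyclopentyl, an open butyl chain or a hydroxyl-bearing cyclohexyl would read at this nitrogen. Also open, going by these compounds, is whether cyclohexyl on the other amine nitrogen would give a similar step.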